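Removing the methyl from the hydroxy oxygen of compound 2

The source may report more compounds than this note shows. Statements on the series, on what has been measured and on what is new or still open speak of the compounds shown alone.

Compounds measured so far:
compound 1 `O=C(Nc1cccc(-n2cc(-c3ccncc3)c(-c3ccc(Cl)c(O)c3)n2)c1)Nc1cccc(C(F)(F)F)c1` — 1910 nM
compound 2 `COc1cc(-c2nn(-c3cccc(NC(=O)Nc4cc(C(F)(F)F)cc(C(F)(F)F)c4)c3)cc2-c2ccncc2)ccc1Cl` — 711 nM
compound 3 `COc1cc(-c2nn(-c3cccc(NC(=O)Nc4cccc(C(F)(F)F)c4)c3)cc2-c2ccncc2)ccc1Cl` — 981 nM

In a functional assay on SNB-19 cells (Homo sapiens) for inhibition, read by sulforhodamine B assay, with a stated time of 48 h (on this read-out higher numbers stand for weaker inhibition of growth and lower numbers for stronger inhibition of growth), compound 2 gives the lowest number of the three, but its gap to compound 3 lies within the scatter, a 1.4-fold higher number from compound 2 to compound 3 (0.14 log units; within the scatter); only compound 1, with 1910 nM, stands apart, beyond the scatter. Compound 4 `O=C(Nc1cccc(-n2cc(-c3ccncc3)c(-c3ccc(Cl)c(O)c3)n2)c1)Nc1cc(C(F)(F)F)cc(C(F)(F)F)c1` is not yet measured. It differs from compound 2 in one place: hydrogen in place of methyl on an oxygen on an aromatic ring, that is, methoxy becomes hydroxy on the 4-chloro-3-methoxyphenyl ring, giving 4-chloro-3-hydroxyphenyl.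

The same change, taken in the opposite direction, was measured between compound 1 and compound 3: a 1.9-fold lower number from compound 1 to compound 3 (0.29 log units; within the scatter). Reversing it suggests a higher number of about the same size for compound 4 in this assay. Compound 4 is therefore expected to land near compound 1, as the step of a 1.9-fold higher number from compound 2 to compound 4 (0.28 log units; within the scatter) would imply. The estimate for compound 4 is 1350 nM, within a range of 700 nM to 2700 nM.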

Compound 4, concentration for 50% growth inhibition: 983 nM
Beside the measured number, compound 4's estimate is 1.4-fold (0.14 log units) above it, within the range that was stated.
By their numbers in this assay, from the lowest: compounds 2, 3, 4 and 1 (each within the scatter of the next, the first and the last beyond it).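

In this assay, the change from methoxy to hydroxy now has a second reading, a 1.4-fold higher number from compound 2 to compound 4 (0.14 log units; within the scatter), so it stays within the scatter with either urea substituent pattern, and the two readings agree: the same change on two cores in this assay, a 1.9-fold lower number (0.29 log units; within the scatter) from compound 1 to compound 3 and a 1.4-fold lower number (0.14 log units; within the scatter) from compound 4 to compound 2, 1.4-fold (0.15 log units) apart, within the scatter of two such steps. The other change, trifluoromethyl in place of hydrogen on an aromatic carbon, reads a 1.9-fold lower number from compound 1 to compound 4 (0.29 log units; within the scatter) among the hydroxy compounds, and it too stays within the scatter and agrees with its reading among the methoxy compounds: the same change on two cores in this assay, a 1.4-fold higher number (0.14 log units; within the scatter) from compound 2 to compound 3 and a 1.9-fold higher number (0.29 log units; within the scatter) from compound 4 to compound 1, 1.4-fold (0.15 log units) apart, within the scatter of two such steps. Among these compounds, neither change taken alone moves the number beyond the scatter.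

The compounds shown leave open whether a longer chain such as ethoxy on that oxygen, or an amine in place of the hydroxy, would give a step beyond the scatter. They also leave open whether either change would read the same on a different core.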